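Amide Nitrogen Substituents on a Shared Core and Paw Edema

The compounds below may be only part of what the source reports. "The series", "measured", "known", "first", "only" and "open" are said of these compounds alone.

The measured compounds:
Compound 1, `O=C(NCc1ccccc1)c1c(O)c2cccnc2n(-c2ccccc2)c1=O`, in a functional assay on the whole organism for inhibition, with Rattus norvegicus as the target, read by paw edema, at a dose of 100 mg/kg by the oral route (on this read-out lower numbers stand for less inhibition and higher numbers for more inhibition at the one dose given (going by the name of the read-out)), gives 1.6%.
Compound 2, `O=C(Nc1cccc([N+](=O)[O-])c1)c1c(O)c2cccnc2n(-c2ccccc2)c1=O`, in this assay gives 5.7%.

Compound 2 carries the larger of the two numbers, but the step of a number 4.1 percentage points higher from compound 1 to compound 2 (within the scatter) leaves the two values within the scatter of each other, so neither compound is set apart. Compound 3, `Cc1cnccc1NC(=O)c1c(O)c2cccnc2n(-c2ccccc2)c1=O`, differs from compound 2 in one place: 3-methylpyridin-4-yl in place of 3-nitrophenyl on an amide-type nitrogen. Among the compounds with values here, the only measured step is the one from compound 1 to compound 2, which also changes the group on the amide-type nitrogen, and it stayed within the scatter. Within the data shown here, there is no measured step in which a pyridinyl group enters, so the change to compound 3 rests on that single small step alone. Because of a number 4.1 percentage points higher from compound 1 to compound 2 (within the scatter) the expected step of a number 0.3 percentage points higher from compound 2 to compound 3 (within the scatter) in this assay is none beyond the scatter. Compound 3 is therefore estimated at 6%, with a range from -4% to 18%.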

Compound 3, a percentage reported as inhibition, in the whole organism at one dose (the size of the read-out at that dose, not a potency): 26.9%
Compound 3: the middle estimate sits 20.9 percentage points below what was measured; measured number outside the range, above it.
By their numbers in this assay, from the lowest: compounds 1 and 2 (each within the scatter of the next); then compound 3.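

In this assay the group on the amide-type nitrogen proves able to move the read-out: 3-methylpyridin-4-yl in place of 3-nitrophenyl gives a number 21.2 percentage points higher from compound 2 to compound 3 (beyond the scatter) and 3-methylpyridin-4-yl in place of benzyl gives a number 25.3 percentage points higher from compound 1 to compound 3 (beyond the scatter). Within the data shown here, the earlier change at this position, a number 4.1 percentage points higher from compound 1 to compound 2 (within the scatter), had not separated the compounds, so this is the first sign that the position is not indifferent, and the gain appears against both of the other groups. Nothing given here bears on what lies behind this gain.

The compounds shown do not separate the ring nitrogen of 3-methylpyridin-4-yl from its methyl, since that group brings both at once. Also open, from the compounds shown here alone, is how a pyridinyl group without the methyl, a methylphenyl group or a carboxylic acid on the ring would read at this position.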